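The source may report more compounds than this note shows. Statements on the series, on what has been measured and on what is new or still open speak of the compounds shown alone.

Working notes on the series. Of the compounds shown here, two carry numbers so far. Compound 1, `CC(C)(C)Cc1cnc(CCc2ccc(-c3ccccc3C(=O)O)cc2)[nH]1`, gives 6.3 nM in an in vitro functional assay on cells for agonist activity at Bombesin receptor subtype-3 (Mus musculus), read by luminescence and calcium flux (on this read-out higher numbers stand for an effect only at larger amounts of compound and lower numbers for an effect already at smaller amounts), and stands as the lower of the two numbers. Among the compounds with values here, compound 2, `CCCCc1cnc(CCCc2ccc(-c3ccccc3C(=O)O)cc2)[nH]1`, gives 382 nM in this assay; the gap from compound 1 to compound 2 lies well beyond the scatter, but no single step is drawn between the pair, so only the two values themselves are noted.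

The step followed here goes from compound 1 to compound 3, `O=C(O)c1ccccc1-c1ccc(CCc2ncc(CC3CC3)[nH]2)cc1`, which has not yet been measured in this assay. The change is cyclopropyl in place of tert-butyl on a saturated chain carbon bound to an aromatic carbon. The neopentyl group on the shared core of compound 1 thus becomes cyclopropylmethyl in compound 3.

Within the data shown here, no measured pair isolates this change, and the number for compound 2 cannot stand in for it. Compound 3 is expected to fall somewhat short of compound 1, with an estimated step of a 4.0-fold higher number from compound 1 to compound 3 (0.60 log units; beyond the scatter), moderate and possibly just beyond the scatter. The estimate for compound 3 in this assay is 25 nM, with a range from 6 nM to 120 nM.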

Compound 3, half-maximal effective concentration: 72 nM
Compound 3: middle estimate off by 2.9-fold (0.46 log units), on the low side, and the stated range covers the measured number.
By their numbers in this assay, from the lowest: compound 1; then compound 3; then compound 2.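

Cyclopropyl in place of tert-butyl on a saturated chain carbon bound to an aromatic carbon gives a large loss in this assay, with an 11-fold higher number from compound 1 to compound 3 (1.06 log units; beyond the scatter), the first step read at this position. The read-out therefore responds strongly here to a change confined to carbon: tert-butyl has 4 heavy atoms and no ring, cyclopropyl has 3 heavy atoms and one three-membered ring, and neither has hydrogen-bond donors, hydrogen-bond acceptors or a net charge. Nothing on hand accounts for the size of this step, and this single pair gives no reason for it.

The compounds shown leave open whether the step follows the ring or the loss of one carbon, a question that isobutyl, which has no ring, and cyclobutylmethyl, which keeps a ring, would help to separate at this place. Within the data shown here, also open is how a group carrying an amine or a hydroxyl would read here, since only groups made of carbon and hydrogen stand at this position so far.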